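Notes on the step to compound 4

This account rests on a few compounds, and the source may have more. Where it says the series, first, only, none or still open, it means among the compounds named here.

Compound 1 (`COc1cc(Nc2ncnc3c(NC(=O)Nc4cc(Cl)cc(Cl)c4)cccc23)cc(OC)c1`) gives 30.2 nM in a functional assay on RT-112 cells (Homo sapiens) for antiproliferative activity, read by MTT assay, with a stated time of 72 h (on this read-out lower numbers stand for stronger inhibition of growth and higher numbers for weaker inhibition of growth), while compound 2 (`COc1cc(Nc2ncnc3c(NC(=O)Nc4ccc(F)cc4C(F)(F)F)cccc23)cc(OC)c1`) gives 2970 nM and compound 3 (`COc1cc(Nc2ncnc3c(NC(=O)Nc4ccc(C(F)(F)F)cc4)cccc23)cc(OC)c1`) gives 3920 nM on the same read-out. Compound 3 stands at the high end of these numbers, where two values agree within the scatter (a 1.3-fold higher number from compound 2 to compound 3 (0.12 log units; within the scatter)) and the gap to the low end is large (a 130-fold higher number from compound 1 to compound 3 (2.11 log units; beyond the scatter)). Compound 4 (`COc1cc(Nc2ncnc3c(NC(=O)c4cc(=O)c5ccccc5o4)cccc23)cc(OC)c1`) differs from compound 3 by one change (a group of 11 heavy atoms (9 carbon, 2 oxygen; one six-membered aromatic ring of carbon only, one six-membered aromatic ring with 1 hetero atom) in place of a group of 11 heavy atoms (7 carbon, 1 nitrogen, 3 fluorine; one six-membered aromatic ring of carbon only), on a carbonyl carbon). Going by the values given here, no measured step covers such a swap. The large step (a 98-fold higher number from compound 1 to compound 2 (1.99 log units; beyond the scatter)) shows how far an exchange of aryl groups alone can move the number, but it gives no firm direction here. A modest move toward a lower number is expected (a 2.6-fold lower number from compound 3 to compound 4 (0.42 log units; beyond the scatter)) with low confidence. Compound 4 is estimated at 1500 nM with a range from 200 nM to 9000 nM as the expected spread.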

Compound 4, concentration for 50% growth inhibition: > 20000 nM
Compound 4 ended at the assay's limit (the forecaster's own chance of this, stated with the estimate: 10%); middle value at least 13-fold (1.12 log units) from the limit.
By their numbers in this assay, from the lowest: compound 1; then compounds 2 and 3 (each within the scatter of the next). At a limit, above all of these: compound 4.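

Compound 4 sits at a limit of this assay, not at a number: the limit of > 20000 nM in this assay, at which 1 of the 4 values shown sits. Replacing the aryl-bearing amide-type nitrogen on the carbonyl carbon with the group of two rings and two oxygens gives an at least 5.1-fold higher number from compound 3 to compound 4 (0.70 log units; beyond the scatter), and the same comparison gives an at least 6.7-fold higher number from compound 2 to compound 4 (0.82 log units; beyond the scatter) and an at least 660-fold higher number from compound 1 to compound 4 (2.82 log units; beyond the scatter). The earlier compounds shown here varied only the aryl group on that nitrogen, whereas this step shows that growth inhibition does not survive removal of the nitrogen with this group, even at an equal heavy-atom count to compound 3.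

Going by these compounds, whether the loss follows from the missing nitrogen or from the entering rings stays open. A plain phenyl group directly on the carbonyl carbon, or a 3,5-dichlorophenyl group there, would separate the two.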